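A few compounds are considered here, and "the series" means these few. Any claim that something is new, unique, unknown or untested is made for them only; others in the source may bear on it.

The series shares one core and one hydroxamic acid chain, and is followed in a functional assay on A549 cells (Homo sapiens) for inhibition, read by MTT assay, with a stated time of 72 h; on this read-out lower numbers stand for stronger inhibition and higher numbers for weaker inhibition. Compound 1 `COc1cc2c(Oc3ccc(NC(=O)c4nn(-c5ccccc5)cc(C)c4=O)cc3)ccnc2cc1OCCCCCCC(=O)NO` gives 420 nM. Compound 2 `COc1cc2c(Oc3ccc(NC(=O)c4nn(-c5ccccc5F)cc(C)c4=O)cc3F)ccnc2cc1OCCCCCC(=O)NO` gives 1320 nM. Compound 3 `COc1cc2c(Oc3ccc(NC(=O)c4nn(-c5ccccc5C)ccc4=O)c(F)c3)ccnc2cc1OCCCCCCC(=O)NO` stands apart: its value of > 20000 nM is a limit of the assay and not a number, as noted in the limit of > 20000 nM in this assay, at which 1 of the 3 values shown sits. Among the three measured compounds, compound 3 is therefore the one for which only a limit is known, while compound 1 and compound 2 each gave a measurable number.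

Compound 4 `COc1cc2c(Oc3ccc(NC(=O)c4nn(-c5ccccc5C)cc(C)c4=O)c(F)c3)ccnc2cc1OCCCCCCC(=O)NO` has not yet been measured in this assay. Compound 4 differs from compound 3 in one place: methyl in place of hydrogen on an aromatic carbon. No step between measured compounds is shown, so the size of this change can only be expected, not read off. Because compound 3 sits at > 20000 nM, and compound 1 and compound 2, which both carry the methyl group, gave numbers, compound 4 is expected to show stronger inhibition than compound 3, by a step beyond the usual scatter, with a fair chance that it too returns only a limit. Compound 4 is estimated at 5000 nM, between 800 nM and 30000 nM, meaning an expected step of an at least 4.0-fold lower number from compound 3 to compound 4 (0.60 log units; beyond the scatter).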

Compound 4, half-maximal inhibitory concentration: 4280 nM
Estimate against measurement, compound 4: 1.2-fold (0.07 log units) above, within the range that was stated.
By their numbers in this assay, from the lowest: compound 1; then compound 2; then compound 4. At a limit, above all of these: compound 3.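

In this assay, methyl in place of hydrogen on an aromatic carbon, opposite the ring nitrogen, gives an at least 4.6-fold lower number from compound 3 to compound 4 (0.66 log units; beyond the scatter). This is the only comparison shown in which that methyl group is the single difference, whereas compound 1 and compound 2 carry the same group but differ from compound 3 in other places as well, and so could not show what it does alone. Compound 4 gives a measurable number, which places the one added carbon as the whole structural difference between a compound that returns a number and one that does not, and the step stands only as a lower bound because compound 3 sits at a limit of the assay: the limit of > 20000 nM in this assay, at which 1 of the 4 values shown sits.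

On these data alone, whether an ethyl group, a chlorine atom or an amine on this same carbon would give a step of similar size remains open. Also open is whether the methyl group would have the same effect alongside the unsubstituted phenyl group of compound 1 or the shorter hydroxamic acid chain of compound 2, as no pair with and without it is shown on those backgrounds.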